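The source may report more compounds than this note shows. Statements on the series, on what has been measured and on what is new or still open speak of the compounds shown alone.

- compound 1 `C=C(Br)C(=O)Nc1ccc(/C=C/C(=O)c2ccc(F)cc2)cc1`: 1600 nM
- compound 2 `C=C(Br)C(=O)Nc1ccc(C(=O)/C=C/c2ccc(OC)c(OC)c2)cc1`: 1300 nM
- compound 3 `Nc1ccc(/C=C/C(=O)c2ccc(F)cc2)cc1`: 123000 nM

These three compounds were tested in a functional assay on L1210 cells (Mus musculus) for antiproliferative activity, with a stated time of 48 h; a higher number here means a weaker inhibitor, a lower number a stronger inhibitor. Compound 3 has the highest number of the three at 123000 nM, and its gaps to both of the others are beyond the scatter. The next compound to consider is compound 4 `Nc1ccc(/C=C/C(=O)c2ccc(I)cc2)cc1`, which has not yet been measured. It differs from compound 3 by one change: iodo in place of fluoro on an aromatic carbon.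

Within the data shown here, the only measured step between two compounds differing in one place is a 77-fold higher number from compound 1 to compound 3 (1.89 log units; beyond the scatter). That step is large, but it comes from hydrogen replacing (1-bromoethenyl)carbonyl on a nitrogen, a different change at a different place. Compound 4 carries the same hydrogen on that nitrogen as compound 3. Among the measured compounds shown here, compound 2 forms no such single-change pair with the others. For the measured compounds named here, no measured pair swaps one halogen for another, so the data give no direction for this change, and no step beyond the scatter is expected. The expected change is a 1.2-fold lower number from compound 3 to compound 4 (0.09 log units; within the scatter). Compound 4 is estimated at 100000 nM, with an expected range of 35000 nM to 280000 nM.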

Compound 4, half-maximal inhibitory concentration: 50000 nM
Beside the measured number, compound 4's estimate is 2.0-fold (0.30 log units) above it; the range from low to high includes it.
By their numbers in this assay, from the lowest: compounds 2 and 1 (each within the scatter of the next); then compound 4; then compound 3.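

In this assay, among these compounds, the change from fluoro to iodo on this aromatic carbon, para to a large group, gives a 2.5-fold lower number from compound 3 to compound 4 (0.39 log units; beyond the scatter) and is the first measured sign that the halogen here affects the read-out, in the direction of a stronger inhibitor. Even so, this step is much smaller than a 77-fold higher number from compound 1 to compound 3 (1.89 log units; beyond the scatter) seen when hydrogen replaces (1-bromoethenyl)carbonyl on the nitrogen, so of the two single changes measured, the one on the nitrogen has the larger effect on the number. Nothing measured here accounts for the shift between the two halogens.

With only fluoro and iodo at this place, the compounds shown leave open how a chloro group or a non-halogen group such as methyl would behave here, and so whether the numbers follow any order across substituents. They also leave open whether the same swap from fluoro to iodo would give a step of similar size and direction in a compound carrying (1-bromoethenyl)carbonyl on the nitrogen, as compound 1 does.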